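The compounds below may be only part of what the source reports. "The series", "measured", "known", "first", "only" and "open" are said of these compounds alone.

In a functional assay on ECa-109 cells for inhibition, with ECa-109 cell line (Homo sapiens) as the target, read by sulforhodamine B assay (on this read-out lower numbers stand for stronger inhibition and higher numbers for weaker inhibition), compound 1 `O=C1C=C(NC2CCCCC2)C(=O)c2c1nc1n2[C@H]2OC[C@@H](O)[C@H]2OC1` reads > 16000 nM, which is a limit of the assay. For the measured compounds named here, compound 2 `Cc1ccc(NC2=CC(=O)c3nc4n(c3C2=O)[C@H]2OC[C@@H](O)[C@H]2OC4)cc1` gives 3480 nM, the only exact number so far. Compound 3 `O=C1C=C(Nc2ccc(I)cc2)C(=O)c2c1nc1n2[C@H]2OC[C@@H](O)[C@H]2OC1` has iodo in place of methyl on an aromatic carbon. Going by the values given here, the one measured step, an at least 4.5-fold lower number from compound 1 to compound 2 (0.66 log units; beyond the scatter), replaced the whole amine substituent, so it bears only indirectly on this smaller change. The expectation therefore stays close to compound 2 at 3480 nM, with no step beyond the scatter foreseen. The expected change is a 1.4-fold lower number from compound 2 to compound 3 (0.14 log units; within the scatter). Compound 3 is estimated at 2500 nM, within a range of 900 nM to 7000 nM.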

Compound 3, half-maximal inhibitory concentration: 2300 nM
Compound 3: the middle estimate sits 1.1-fold (0.04 log units) above what was measured; measured number inside the range.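

Going from 4-methylphenyl to 4-iodophenyl gives a 1.5-fold lower number from compound 2 to compound 3 (0.18 log units; within the scatter), so on this aromatic carbon iodo stands in for methyl without a change that can be read. The preference for an aromatic group over cyclohexyl on the amine nitrogen now rests on a second compound, with an at least 6.9-fold lower number from compound 1 to compound 3 (0.84 log units; beyond the scatter). Compound 1 is a limit of the assay, so that step has no upper size: the limit of > 16000 nM in this assay, at which 1 of the 3 values shown sits.

Open, going by these compounds, is how an unsubstituted phenyl, or a hydroxyl, an amine or a carboxylic acid on this aromatic carbon, would read. Also open, on these data alone, is how a benzyl group on the amine nitrogen would compare.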